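The source may hold more compounds than are shown below. What is called first, only, known or untested is meant among the compounds shown, and "the series" means these compounds.

Measured so far in a functional assay on A549 cells (Homo sapiens) for inhibition, read by MTT assay, with a stated time of 24 h; a higher number here means a weaker inhibitor, a lower number a stronger inhibitor:
- Compound 1 `CC1(C)[C@H]2CC[C@]1(C)N(Cc1cn(-c3ccccc3C#N)nn1)C(=O)C2`: 100 nM
- Compound 2 `CC1(C)[C@H]2CC[C@]1(C)N(Cc1cn(-c3cccc(C#N)c3)nn1)C(=O)C2`: 440 nM
- Compound 3 `CC1(C)[C@H]2CC[C@]1(C)N(Cc1cn(-c3ccccc3F)nn1)C(=O)C2`: 240 nM

Compound 3 sits among these three as follows: there is a 2.4-fold higher number from compound 1 to compound 3 (0.38 log units; beyond the scatter), and there is a 1.8-fold lower number from compound 2 to compound 3 (0.26 log units; within the scatter). Its number therefore cannot be told apart from that of compound 2, but it can be told apart from that of compound 1.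

The next compound is compound 4 `CC1(C)[C@H]2CC[C@]1(C)N(Cc1cn(-c3cccc(Cl)c3)nn1)C(=O)C2`, which keeps the shared core and carries 3-chlorophenyl in place of 2-fluorophenyl on an aromatic nitrogen. For the measured compounds named here, no chlorine-bearing compound has been measured, so any expectation rests on indirect evidence. The closest guide is the move of the nitrile, with a 4.4-fold higher number from compound 1 to compound 2 (0.64 log units; beyond the scatter), a modest step towards a higher number. Going by the values given here, compound 2, the one measured compound with a group named at the 3 position of its phenyl, gives 440 nM. A chlorine need not behave like a nitrile, so this guide is loose.

The expected change is a 1.6-fold higher number from compound 3 to compound 4 (0.20 log units; within the scatter), a small rise in the number that would not stand clear of the scatter. For compound 4 the estimated value is 380 nM, with an expected range of 150 nM to 900 nM.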

Compound 4, half-maximal inhibitory concentration: 60 nM
The estimate for compound 4 lay 6.3-fold (0.80 log units) above the measured number, outside the stated range (below it).
By their numbers in this assay, from the lowest: compounds 4 and 1 (each within the scatter of the next); then compounds 3 and 2 (each within the scatter of the next).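

In this assay the change to 3-chlorophenyl on the aromatic nitrogen brings a 4.0-fold lower number from compound 3 to compound 4 (0.60 log units; beyond the scatter) and putting chloro in place of the cyano of 3-cyanophenyl brings a 7.3-fold lower number from compound 2 to compound 4 (0.87 log units; beyond the scatter) so the high number of compound 2 cannot be read as a cost of every group placed as in 3-cyanophenyl. The comparison with the best earlier compound gives a 1.7-fold lower number from compound 1 to compound 4 (0.22 log units; within the scatter) and that gap lies within the scatter, so 3-chlorophenyl and 2-cyanophenyl cannot be told apart here, even though the nitrile lost ground when it moved from its place in compound 1 to its place in compound 2. These compounds show that the identity of the group on the phenyl ring matters as much as where it sits, but nothing available explains why chloro and cyano differ so sharply on this ring.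

Going by these compounds, it remains open whether the low number belongs to chlorine itself or would also appear with 3-bromophenyl, 3-methylphenyl or 3-methoxyphenyl. A 2-chlorophenyl group would show whether chlorine responds to its position on the ring as the nitrile does, and a 3-aminophenyl group would test a very different kind of substituent in the same place.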